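A few compounds are considered here, and "the series" means these few. Any claim that something is new, unique, unknown or untested is made for them only; others in the source may bear on it.

The series shares the core of compound 2 `CCCOc1cc(NC(=O)NNc2cc(-c3ccc(OC)cc3)c3cnn(C)c3n2)cc(Cl)n1`. In a functional assay on SW620/5-FU cells (Homo sapiens) for cytotoxicity, read by MTT assay, with a stated time of 48 h, in the presence of a further agent that is not named here (a lower number here means that less compound is needed, a higher number that more compound is needed for the effect), compound 2 gives 37200 nM. Compound 3 `CCCCOc1cc(NC(=O)NNc2cc(-c3ccc(OC)cc3)c3cnn(C)c3n2)cc(Cl)n1` gives 39200 nM, and compound 1 `COc1ccc(-c2cc(NNC(=O)Nc3cc(Cl)nc(OC)c3)nc3c2cnn3C)cc1` gives 48800 nM. The steps of a 1.3-fold lower number from compound 1 to compound 2 (0.12 log units; within the scatter) and a 1.1-fold higher number from compound 2 to compound 3 (0.02 log units; within the scatter) both sit within the scatter, so the three numbers cannot be told apart. Compound 4 `COc1ccc(-c2cc(NNC(=O)Nc3cc(Br)nc(Br)c3)nc3c2cnn3C)cc1` carries 2,6-dibromopyridin-4-yl in place of 2-chloro-6-propoxypyridin-4-yl on an amide-type nitrogen. Among the measured compounds shown here, no measured step touches a swap of this kind: the only changes measured are in the chain on the aromatic oxygen, and none moved the number beyond the scatter, so the three numbers give no direction for this ring swap. Compound 4 is therefore expected close to the measured group, with an estimated step of a 1.1-fold higher number from compound 2 to compound 4 (0.03 log units; within the scatter). The estimate for compound 4 is 40000 nM, set wide, from 15000 nM to 110000 nM.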

Compound 4, half-maximal effective concentration: 54100 nM
Estimate against measurement, compound 4: 1.4-fold (0.13 log units) below; the range from low to high includes it.
By their numbers in this assay, from the lowest: compounds 2, 3, 1 and 4 (each within the scatter of the next).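

On the amide-type nitrogen, 2,6-dibromopyridin-4-yl can replace 2-chloro-6-propoxypyridin-4-yl (a 1.5-fold higher number from compound 2 to compound 4 (0.16 log units; within the scatter)) or 2-chloro-6-methoxypyridin-4-yl (a 1.1-fold higher number from compound 1 to compound 4 (0.04 log units; within the scatter)) with both steps staying within the scatter. In this assay, exchanging the substituents on the pyridine ring therefore gives no more separation than changing the chain on the oxygen did. No supporting measurement bears on this result.

On these data alone, whether any group at this position can move the number beyond the scatter remains open. An amine or a carboxylic acid in place of a bromine of compound 4 would test this.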